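A few compounds are considered here, and "the series" means these few. Any claim that something is new, unique, unknown or untested is made for them only; others in the source may bear on it.

Compound 1 `CCCC[C@@H](/C=C\[C@@H]1OC(=O)C=C[C@@H]1O)OC(C)=O` gives 0.8 ug/mL in a functional assay on A-431 cells (Homo sapiens) for cytotoxicity, read by sulforhodamine B assay, with a stated time of 72 h; on this read-out lower numbers stand for an effect already at smaller amounts and higher numbers for an effect only at larger amounts of compound. Compound 2 `CCCC[C@@H](/C=C\[C@@H]1OC(=O)C=C[C@@H]1OC(C)=O)OC(C)=O` gives 1.4 ug/mL in this assay; it holds the higher of the two measured numbers on paper, but since a 1.8-fold higher number from compound 1 to compound 2 (0.24 log units; within the scatter) is within the scatter the two compounds cannot be told apart. Compound 3 `CCCC[C@H](O)/C=C\[C@@H]1OC(=O)C=C[C@@H]1OC(C)=O` differs from compound 2 by hydrogen in place of acetyl on an oxygen on a saturated carbon. Among the compounds with values here, only the step from compound 1 to compound 2, which also concerns an acetyl on an oxygen and stayed within the scatter, bears on this change, so no step beyond the scatter is expected: a 1.2-fold lower number from compound 2 to compound 3 (0.07 log units; within the scatter). Compound 3 is therefore estimated at 1.2 ug/mL, between 0.5 ug/mL and 3 ug/mL.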

Compound 3, concentration for half-maximal effect: 0.6 ug/mL
Compound 3: middle estimate off by 2.0-fold (0.30 log units), on the high side; measured number inside the range.
By their numbers in this assay, from the lowest: compounds 3, 1 and 2 (each within the scatter of the next, the first and the last beyond it).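

Within the data shown here, replacing acetyl with hydrogen on this oxygen on a saturated carbon, acetoxy to hydroxy, gives a 2.3-fold lower number from compound 2 to compound 3 (0.37 log units; beyond the scatter) in this assay and is the first change here to pass the scatter, if only modestly. The earlier acetyl change on the other oxygen, a 1.8-fold higher number from compound 1 to compound 2 (0.24 log units; within the scatter) stayed within it. No measurement available here explains this shift.

From the compounds shown here alone, whether a methyl ether or a longer ester such as butyrate on this oxygen would move the number further remains open. So does the effect of an amine in place of this oxygen.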